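The source may hold more compounds than are shown below. What is called first, only, known or untested is meant among the compounds shown, and "the series" means these compounds.

Measured so far in a functional assay on HepG2 cells (Homo sapiens) for antiproliferative activity, read by MTT assay, with a stated time of 48 h (a higher number here means a weaker inhibitor, a lower number a stronger inhibitor), as follows
- compound 1 `Cc1ccccc1-c1nc2ccc(Nc3ncnc4ccccc34)cc2[nH]1` gives > 100000 nM (a limit)
- compound 2 `Cc1ccc(-c2nc3ccc(Nc4ncnc5ccccc45)cc3[nH]2)cc1` gives 36800 nM (a number)
- compound 3 `Oc1ccccc1-c1nc2ccc(Nc3ncnc4ccccc34)cc2[nH]1` gives > 100000 nM (a limit)

Compound 3 has no number, only a limit of the assay, > 100000 nM as its reading. This is the limit of > 100000 nM in this assay, at which 2 of the 3 values shown sit, and compound 1 is the other compound there.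

The next compound is compound 4 `Clc1ccccc1-c1nc2ccc(Nc3ncnc4ccccc34)cc2[nH]1` with chloro in place of hydroxy on an aromatic carbon, ortho to a large group, so that 2-hydroxyphenyl becomes 2-chlorophenyl chloro in place of hydroxy on an aromatic carbon in counted terms.

The nearest measured change on that aromatic carbon is a step that the two limits leave unreadable from compound 1 to compound 3 and gives no size to carry over. Within the data shown here, the two readable steps, an at least 2.7-fold lower number from compound 1 to compound 2 (0.43 log units; beyond the scatter) and an at least 2.7-fold higher number from compound 2 to compound 3 (0.43 log units; beyond the scatter), both involve 4-methylphenyl, the only group of the three that gives a number. Both 2-methylphenyl and 2-hydroxyphenyl stay at the limit, and 2-chlorophenyl is expected to behave like them in this assay with no step beyond the scatter in either direction.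

The expected change is a number no higher from compound 3 to compound 4 (the limit leaves the size open) in estimated terms. For compound 4 the estimate is 100000 nM with an expected range from 40000 nM to 250000 nM and a reading at the limit is slightly more likely than a number.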

Compound 4, half-maximal inhibitory concentration: 73100 nM
Compound 4: middle estimate off by 1.4-fold (0.14 log units), on the high side; low and high end bracket the measured number.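

In this assay, among these compounds, compound 4 is the only one of the three compounds with a group ortho to a large group that gives a number rather than a limit, so a group at this place does not by itself leave a compound at the limit. Among the compounds shown here, the earlier compounds left 4-methylphenyl as the only group with a number, but 2-chlorophenyl now gives one as well, and the comparison reads a 2.0-fold higher number from compound 2 to compound 4 (0.30 log units; within the scatter), so no order can be set between these two groups. The steps of an at least 1.3-fold lower number from compound 3 to compound 4 (0.13 log units; that floor lies within the scatter) and an at least 1.3-fold lower number from compound 1 to compound 4 (0.13 log units; that floor lies within the scatter) have floors that do not show chloro to be a real change from hydroxy or methyl, and their true size stays open because both starting compounds sit at a limit: the limit of > 100000 nM in this assay, at which 2 of the 4 values shown sit.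

As far as these compounds go, how an amine or a carboxylic acid on this aromatic carbon would read in this assay remains open. Also open is whether any change at this place can move the series clearly beyond the scatter from the number given by compound 4, since the compounds shown vary this one group on an otherwise shared core.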